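This account rests on a few compounds, and the source may have more. Where it says the series, first, only, none or still open, it means among the compounds named here.

Measured so far:
compound 1, `CCOC(=O)/C=C/c1ccncc1-c1ccc2c(ccn2C)c1`, in a functional assay on MDA-MB-231 cells (Homo sapiens) for inhibition, read by sulforhodamine B assay, with a stated time of 72 h; a higher number here means a weaker inhibitor of growth, a lower number a stronger inhibitor of growth: 10200 nM
compound 2, `CNC(=O)/C=C/c1ccncc1-c1ccc2[nH]ccc2c1`, in this assay a limit and not a number: > 10000 nM
compound 3, `CNC(=O)CCc1ccncc1-c1ccc2ccccc2c1`, in this assay: 8980 nM

Compound 3 and compound 1 give numbers within the usual scatter of each other, so neither stands apart. Compound 2 sits at the limit of > 10000 nM in this assay, at which 1 of the 3 values shown sits, and adds no number. Compound 4, `O=C(O)/C=C/c1ccncc1-c1ccc2ccccc2c1`, has not yet been measured in this assay. It differs from compound 3 in one place: 2-carboxyethenyl in place of 2-(methylcarbamoyl)ethyl on an aromatic carbon. Going by the values given here, no measured pair matches this change, so its size cannot be read from the numbers at hand. The step from compound 3 to compound 4 is expected to be small, likely none beyond the scatter: a 1.3-fold higher number from compound 3 to compound 4 (0.13 log units; within the scatter). Compound 4 is therefore estimated at 12000 nM, within 4000 nM to 40000 nM, with a fair chance that only a limit is returned.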

Compound 4, concentration for 50% growth inhibition: > 10000 nM
Compound 4 ended at the assay's limit; the forecaster's own chance of this, stated with the estimate: 45%; the middle value is on the limit's open side.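

In this assay, 2-carboxyethenyl in place of 2-(methylcarbamoyl)ethyl on this aromatic carbon gives an at least 1.1-fold higher number from compound 3 to compound 4 (0.04 log units; that floor lies within the scatter). That step is only a floor, so the change brings no gain in growth inhibition, and its true size cannot be read. Compound 4 gives a limit of the assay and not a number: the limit of > 10000 nM in this assay, at which 2 of the 4 values shown sit.

Still open, from the compounds shown here alone, is whether a saturated 2-carboxyethyl chain at this position would return a number rather than a limit. Also open, going by these compounds, is whether an amine or a longer chain here would move the value beyond the scatter.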